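Methyl for Methoxy on the Aryl Ring of Compound 1

This account rests on a few compounds, and the source may have more. Where it says the series, first, only, none or still open, it means among the compounds named here.

Compound 1 `COc1ccc(-c2nnc(NC(=O)/C=C/c3ccccc3)s2)cc1` gives 0.68 ug/mL in a functional assay on A549 cells (Homo sapiens) for antiproliferative activity, read by MTT assay, with a stated time of 48 h (a higher number here means a weaker inhibitor, a lower number a stronger inhibitor), the lowest of the three numbers shown. Compound 2 `COc1ccc(/C=C/C(=O)Nc2nnc(-c3ccc(Br)cc3)s2)cc1` gives 1.04 ug/mL, and compound 3 `Cc1ccc(/C=C/C(=O)Nc2nnc(-c3ccc(Br)cc3)s2)cc1` gives 1.51 ug/mL; the gap from compound 1 to compound 2 is within the scatter, while the gap from compound 1 to compound 3 lies beyond it. Compound 4 `Cc1ccc(-c2nnc(NC(=O)/C=C/c3ccccc3)s2)cc1` differs from compound 1 by methyl in place of methoxy on an aromatic carbon. Among the compounds with values here, the one measured step that bears on this change is a 1.5-fold higher number from compound 2 to compound 3 (0.16 log units; within the scatter), which lay within the scatter. Compound 4 is therefore expected to show no shift beyond the scatter, with at most a modest rise, so that a 1.4-fold higher number from compound 1 to compound 4 (0.15 log units; within the scatter) is the expected step. The estimate for compound 4 is 0.95 ug/mL, with a range from 0.5 ug/mL to 1.8 ug/mL.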

Compound 4, half-maximal inhibitory concentration: 1.38 ug/mL
Estimate against measurement, compound 4: 1.5-fold (0.16 log units) below; low and high end bracket the measured number.
By their numbers in this assay, from the lowest: compounds 1, 2, 4 and 3 (each within the scatter of the next, the first and the last beyond it).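

Within the data shown here, the step of a 2.0-fold higher number from compound 1 to compound 4 (0.31 log units; beyond the scatter) is the first reading of methyl in place of methoxy that passes beyond the scatter, and it shows that the 4-methoxyphenyl to 4-methylphenyl change can matter at this position. The direction is the same on both cores, and the two steps cannot be told apart in size: the same change on two cores in this assay, a 1.5-fold higher number (0.16 log units; within the scatter) from compound 2 to compound 3 and a 2.0-fold higher number (0.31 log units; beyond the scatter) from compound 1 to compound 4, 1.4-fold (0.15 log units) apart, within the scatter of two such steps.

The compounds shown leave open how a hydroxyl, an amine or a carboxylic acid would read at this place. They also leave open whether a longer chain, such as ethoxy, would keep the number of methoxy.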